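A Fluorine Added to the Methylphenyl Arm

This account rests on a few compounds, and the source may have more. Where it says the series, first, only, none or still open, it means among the compounds named here.

Measured so far:
compound 1 `CCCS(=O)(=O)Nc1ccc(F)c(C(=O)c2n[nH]c3ncc(-c4ccc(F)cc4)cc23)c1F`: 2.1%
compound 2 `CCCS(=O)(=O)Nc1ccc(F)c(C(=O)c2n[nH]c3ncc(-c4ccccc4C)cc23)c1F`: 7%
compound 3 `CCCS(=O)(=O)Nc1ccc(F)c(C(=O)c2n[nH]c3ncc(-c4ccc(C)c(C)c4)cc23)c1F`: 20%

In an assay for binding affinity to dual specificity mitogen-activated protein kinase kinase 4 (Homo sapiens), read by KINOMEscan, tested at 100 nM (on this read-out higher numbers stand for a weaker effect at the one concentration tested and lower numbers for a stronger effect), compound 2 gives 7%, the second highest of the three numbers. Compound 1 gives 2.1%, a gap covered by a number 4.9 percentage points higher from compound 1 to compound 2 (within the scatter); compound 3 gives 20%, reached by a number 13 percentage points higher from compound 2 to compound 3 (beyond the scatter). Compound 4 `CCCS(=O)(=O)Nc1ccc(F)c(C(=O)c2n[nH]c3ncc(-c4ccc(F)cc4C)cc23)c1F` differs from compound 2 by fluoro in place of hydrogen on an aromatic carbon. Within the data shown here, no measured pair swaps hydrogen for fluoro alone. The closest guide is compound 1, which also carries a fluoro group, and its step to compound 2 stayed within the scatter: a number 4.9 percentage points higher from compound 1 to compound 2 (within the scatter). A step within the scatter is therefore expected, estimated as a number 2.5 percentage points lower from compound 2 to compound 4 (within the scatter). Compound 4 is expected near 4.5%, between 1% and 13%.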

Compound 4, a percentage reported as activity, at one concentration (the size of the read-out at that concentration, not a potency): 14%
The estimate for compound 4 lay 9.5 percentage points below the measured number; measured number above the stated range.
By their numbers in this assay, from the lowest: compounds 1, 2, 4 and 3 (each within the scatter of the next, the first and the last beyond it).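

In this assay, fluoro para to a large group cannot be told apart from hydrogen, with a number 7 percentage points higher from compound 2 to compound 4 (within the scatter), and 4-fluoro-2-methylphenyl cannot be told apart from 3,4-dimethylphenyl, with a number 6 percentage points lower from compound 3 to compound 4 (within the scatter). The clearer signal comes from the methyl group: with the fluoro kept in place, methyl in place of hydrogen gives a number 11.9 percentage points higher from compound 1 to compound 4 (beyond the scatter). No measurement given here accounts for these numbers. On these data alone, whether an amine or a methoxy group at the fluoro position would read differently remains open, as does the effect of a longer chain in place of the methyl.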